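Ethynyl to vinyl on the side chain of compound 3

The source may hold more compounds than are shown below. What is called first, only, known or untested is meant among the compounds shown, and "the series" means these compounds.

Compound 3 `C#CCC[C@H]1O[C@@H](C)[C@H](C)C(Cl)=C1[Si](C)(C)C` gives 39000 nM in a functional assay on A2780 cells (Homo sapiens) for antiproliferative activity (a higher number here means a weaker inhibitor of growth, a lower number a stronger inhibitor of growth), the highest of the three numbers, though both neighbours sit within the scatter of it: compound 1 `C[C@@H]1O[C@H](C2CCCCC2)C([Si](C)(C)C)=C(Cl)[C@H]1C` gives 38000 nM and compound 2 `C[C@@H]1O[C@H](CCC=C(Br)Br)C([Si](C)(C)C)=C(Cl)[C@H]1C` gives 33000 nM. The steps of a 1.0-fold higher number from compound 1 to compound 3 (0.01 log units; within the scatter) and a 1.2-fold higher number from compound 2 to compound 3 (0.07 log units; within the scatter) are within the scatter, as is a 1.2-fold lower number from compound 1 to compound 2 (0.06 log units; within the scatter). Compound 4 `C=CCC[C@H]1O[C@@H](C)[C@H](C)C(Cl)=C1[Si](C)(C)C` differs from compound 3 by vinyl in place of ethynyl on a saturated chain carbon, two bonds along the chain from a saturated ring carbon. The step of a 1.2-fold higher number from compound 2 to compound 3 (0.07 log units; within the scatter), which alters the group on the same saturated chain carbon, bears most directly on this change and moved nothing; the exchange of whole side chains in a 1.0-fold higher number from compound 1 to compound 3 (0.01 log units; within the scatter) likewise moved nothing. No step beyond the scatter is therefore expected in this assay. Compound 4 is expected to give about 38000 nM, between 19000 nM and 76000 nM, a step of a 1.0-fold lower number from compound 3 to compound 4 (0.01 log units; within the scatter) expected to stay within the scatter.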

Compound 4, concentration for total growth inhibition: 36000 nM
The estimate for compound 4 lay 1.1-fold (0.02 log units) above the measured number; the range from low to high includes it.
By their numbers in this assay, from the lowest: compounds 2, 4, 1 and 3 (each within the scatter of the next).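

In this assay, the but-3-yn-1-yl chain can give way to but-3-en-1-yl without a step beyond the scatter (a 1.1-fold lower number from compound 3 to compound 4 (0.03 log units; within the scatter)). The vinyl end also stays within the scatter of the 2,2-dibromoethenyl end (a 1.1-fold higher number from compound 2 to compound 4 (0.04 log units; within the scatter)), and the but-3-en-1-yl chain of the cyclohexyl group (a 1.1-fold lower number from compound 1 to compound 4 (0.02 log units; within the scatter)), so no side chain among these four compounds stands apart. No supporting data explain this flat response.

On these data alone, whether an amine, a carboxylic acid or a longer chain at this place would produce a step beyond the scatter remains open.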